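This account rests on a few compounds, and the source may have more. Where it says the series, first, only, none or still open, it means among the compounds named here.

Working notes on the series. The shared core of compound 1 `COc1cccc(OC)c1C(=O)Nc1c[nH]nc1C(=O)NC1CCC1` carries a cyclobutyl on the amide-type nitrogen. In an ADME assay on MRC5 cells (Homo sapiens) for inhibition, with a stated time of 72 h (on this read-out higher numbers stand for an effect only at larger amounts of compound and lower numbers for an effect already at smaller amounts), compound 1 gives only a limit of the assay, > 50000 nM, and therefore stands at the far end of the numbers shown, as noted in the limit of > 50000 nM in this assay, at which 1 of the 3 values shown sits. Two further members carry another amine on that carbonyl: compound 2 `CO[C@H]1CC[C@H](NC(=O)c2n[nH]cc2NC(=O)c2ccc(OC(F)F)cc2)CC1` gives 2500 nM in this assay, and compound 3 `CO[C@H]1CC[C@H](NC(=O)c2n[nH]cc2NC(=O)c2ccccc2)CC1` gives 800 nM. Among the compounds with values here, the single measured step between neighbours, a 3.1-fold lower number from compound 2 to compound 3 (0.49 log units; beyond the scatter), sits on an aromatic carbon and not on the amide-type nitrogen varied here.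

The unmeasured compound 4 `COc1cccc(OC)c1C(=O)Nc1c[nH]nc1C(=O)Nc1ccccc1` differs from compound 1 in one place: phenyl in place of cyclobutyl on an amide-type nitrogen. Within the data shown here, no measured step bears on this change, so the expectation rests on where compound 1 stands alone. Because compound 1 gives > 50000 nM in this assay, the starting point is already a limit and not a number. The step from compound 1 to compound 4 is accordingly expected to be small, an at least 1.6-fold lower number from compound 1 to compound 4 (0.22 log units; that floor lies within the scatter), with a real chance that the assay once more reports only a limit. For compound 4 the estimated value is 30000 nM, in a range from 8000 nM to 100000 nM.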

Compound 4, half-maximal effective concentration: > 50000 nM
Compound 4 gave a limit, no number; the forecaster's own chance of this, stated with the estimate: 60%; middle value at least 1.6-fold (0.22 log units) from the limit.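

Compound 4, like compound 1, ends at a limit of this assay and not at a number, so no step can be read for phenyl in place of cyclobutyl on an amide-type nitrogen: the limit of > 50000 nM in this assay, at which 2 of the 4 values shown sit.

The compounds shown leave open whether phenyl and cyclobutyl differ at all on this read-out on the shared core of compound 1.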